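From 3-methoxyphenyl to 4-methoxy-2-methylphenyl on the shared core

The compounds below may be only part of what the source reports. "The series", "measured", "known", "first", "only" and "open" are said of these compounds alone.

In an ADME assay (liver) for metabolic stability, with Liver microsome (Canis lupus familiaris) as the target, read by LC-MS, using microsomes, with a stated time of 30 min, tested at 4 uM (on this read-out higher numbers stand for a more stable compound and lower numbers for a less stable compound), compound 1 `CCN1CCN(c2nc(C)nc3c2nc(-c2ccccc2Cl)n3CCOC)CC1` gives 86%, compound 2 `COc1ccccc1-c1nc2c(N3CCN(C)CC3)nc(C)nc2n1C1CCOCC1` gives 36% and compound 3 `COc1cccc(-c2nc3c(N4CCN(C)CC4)nc(C)nc3n2C2CCOCC2)c1` gives 46%. Compound 3 therefore stands far beneath compound 1 and within the scatter of compound 2. Compound 4 `COc1ccc(-c2nc3c(N4CCN(C)CC4)nc(C)nc3n2C2CCOCC2)c(C)c1` carries one structural change from compound 3: 4-methoxy-2-methylphenyl in place of 3-methoxyphenyl on an aromatic carbon. Going by the values given here, the only measured step on this aromatic group is a number 10 percentage points higher from compound 2 to compound 3 (within the scatter), and it stays within the scatter. Among the compounds with values here, no other measured step touches this group, so the evidence is thin. No step beyond the scatter is therefore expected in this assay, and the estimated change is a number 2 percentage points lower from compound 3 to compound 4 (within the scatter). For compound 4 the estimated value is 44%, with an expected range from 26% to 62%.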

Compound 4, percent of the compound remaining: 41%
Compound 4: middle estimate off by 3 percentage points, on the high side; the measured number falls inside the stated range.
By their numbers in this assay, from the lowest: compounds 2, 4 and 3 (each within the scatter of the next); then compound 1.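

In this assay, 4-methoxy-2-methylphenyl in place of 3-methoxyphenyl gives a number 5 percentage points lower from compound 3 to compound 4 (within the scatter), and in place of 2-methoxyphenyl it gives a number 5 percentage points higher from compound 2 to compound 4 (within the scatter). All three methoxy-bearing phenyl groups at this position now lie within the scatter of one another, so neither the added methyl nor the different methoxy placement leaves a readable mark here. No measurement at hand offers an explanation for this. Still open, going by these compounds, is whether this position can shift the number at all, for instance with an amine or a carboxylic acid on the phenyl ring in place of the methoxy group.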